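The compounds below may be only part of what the source reports. "The series", "measured", "known", "first", "only" and "open" are said of these compounds alone.

Compound 1 `COc1cc(-c2cc(/C=C/C(=O)c3ccc(N)cc3)[nH]n2)cc(OC)c1OC` gives 4710 nM in a functional assay on Malme-3M cells (Homo sapiens) for inhibition, read by sulforhodamine B assay, with a stated time of 48 h; a higher number here means a weaker inhibitor of growth, a lower number a stronger inhibitor of growth.
Compound 2 `COc1cc(-c2cc(/C=C/C(=O)c3ccc(Cl)c(Cl)c3)[nH]n2)cc(OC)c1OC` reaches only the limit > 100000 nM in this assay.
Compound 3 `COc1ccc(C(=O)/C=C/c2cc(-c3cc(OC)c(OC)c(OC)c3)n[nH]2)cc1` gives 3850 nM in this assay.

Compound 3 holds the lowest of the two numbers shown, but compound 1 sits within the scatter of it, with a 1.2-fold lower number from compound 1 to compound 3 (0.09 log units; within the scatter), so the two cannot be told apart. Compound 4 `COc1cc(-c2cc(/C=C/C(=O)c3ccc(F)c(F)c3)[nH]n2)cc(OC)c1OC` differs from compound 3 by 3,4-difluorophenyl in place of 4-methoxyphenyl on a carbonyl carbon. Among the measured compounds shown here, two measured steps bear on this change, both of them swapping a 3,4-dichlorophenyl in or out on the carbonyl carbon: an at least 21-fold higher number from compound 1 to compound 2 (1.32 log units; beyond the scatter), and an at least 25-fold lower number from compound 2 to compound 3 (1.41 log units; beyond the scatter). Compound 2 sits at the limit of this assay (the limit of > 100000 nM in this assay, at which 1 of the 3 values shown sits). The 3,4-difluorophenyl of compound 4 is closest in kind to that 3,4-dichlorophenyl, so a large rise in this assay is expected, a 10-fold higher number from compound 3 to compound 4 (1.02 log units; beyond the scatter), with a real chance that only a limit is reported. Compound 4 is therefore estimated at 40000 nM in this assay, within a range of 8000 nM to 200000 nM.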

Compound 4, concentration for total growth inhibition: 9400 nM
For compound 4 the middle estimate is 4.3-fold (0.63 log units) above the measured one; low and high end bracket the measured number.
By their numbers in this assay, from the lowest: compounds 3, 1 and 4 (each within the scatter of the next, the first and the last beyond it). At a limit, above all of these: compound 2.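

Halogens on this phenyl do not all act alike in this assay: replacing the 3,4-dichlorophenyl on the carbonyl carbon with 3,4-difluorophenyl gives an at least 10-fold lower number from compound 2 to compound 4 (1.02 log units; beyond the scatter). The figure for compound 2 is a limit and not a number: the limit of > 100000 nM in this assay, at which 1 of the 4 values shown sits. Replacing the 4-methoxyphenyl costs only a modest step, a 2.4-fold higher number from compound 3 to compound 4 (0.39 log units; beyond the scatter), while replacing the 4-aminophenyl gives a 2.0-fold higher number from compound 1 to compound 4 (0.30 log units; within the scatter), so compound 4 cannot be told apart from compound 1.

On these data alone, it remains open whether a single fluorine, a single chlorine or a trifluoromethyl on this phenyl would follow the 3,4-difluorophenyl or the 3,4-dichlorophenyl. As far as these compounds go, it is also open whether a hydroxyl or a dimethylamino group in the place of the methoxy or amino group would stay level with compound 3 and compound 1.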